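The source may report more compounds than this note shows. Statements on the series, on what has been measured and on what is new or still open speak of the compounds shown alone.

Measured in a functional assay on SW480 cells (Homo sapiens) for inhibition; on this read-out lower numbers stand for stronger inhibition and higher numbers for weaker inhibition:

- compound 1 `COc1cc[nH]c1/C=C1\C(=O)Nc2ccc(F)c(C#C[C@H](N)CO)c21`: 270 nM
- compound 2 `CCN[C@H](C#Cc1c(F)ccc2c1/C(=C/c1[nH]ccc1OC)C(=O)N2)[C@@H](C)O`: 549 nM

Compound 2 has the higher of the two numbers, at 549 nM, which makes it the weaker inhibitor of the pair. The next compound to be tested is compound 3 `COc1cc[nH]c1/C=C1\C(=O)Nc2ccc(F)c(C#C[C@@H]3C[C@H](O)CN3)c21`, and the change from compound 2 is 4-hydroxypyrrolidin-2-yl in place of 1-(ethylamino)-2-hydroxypropyl on a triple-bonded carbon. Put simply, 4-hydroxypyrrolidin-2-yl takes the place of 1-(ethylamino)-2-hydroxypropyl on a triple-bonded carbon, with the shared core unchanged.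

Within the data shown here, only one measured step bears on this change: a 2.0-fold higher number from compound 1 to compound 2 (0.31 log units; beyond the scatter), a modest one, with 1-(ethylamino)-2-hydroxypropyl in place of 1-amino-2-hydroxyethyl at the same carbon. Among the measured compounds shown here, no measured compound carries the ring, so the evidence is thin. For the measured compounds named here, the expectation in this assay is a small move towards a lower number, no larger than that step, resting on compound 1 at 270 nM. The expected step is a 1.8-fold lower number from compound 2 to compound 3 (0.26 log units; within the scatter). For compound 3 the estimated value is 300 nM, with an expected range of 100 nM to 900 nM.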

Compound 3, half-maximal inhibitory concentration: 90 nM
The estimate for compound 3 lay 3.3-fold (0.52 log units) above the measured number; measured number outside the range, below it.
By their numbers in this assay, from the lowest: compound 3; then compound 1; then compound 2.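

In this assay, putting 4-hydroxypyrrolidin-2-yl in place of 1-(ethylamino)-2-hydroxypropyl on the triple-bonded carbon gives a 6.1-fold lower number from compound 2 to compound 3 (0.79 log units; beyond the scatter), and putting it in place of 1-amino-2-hydroxyethyl gives a 3.0-fold lower number from compound 1 to compound 3 (0.48 log units; beyond the scatter), so compound 3 has the lowest number of the three. The earlier compounds shown here showed only a modest difference between two open chains, whereas this result shows that the position accepts a group with a five-membered non-aromatic ring and that this group gives a lower number than either chain, even though it has the same counts of hydrogen-bond donors and acceptors as the 1-(ethylamino)-2-hydroxypropyl group it replaces. Nothing available explains why the ring goes with the lower number.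

The compounds shown leave open how much of this gain depends on the ring hydroxyl, which an unsubstituted pyrrolidin-2-yl group would test, and how much depends on ring size, which a piperidin-2-yl group would test. They also leave open whether the two defined stereocentres of the 4-hydroxypyrrolidin-2-yl group matter, and whether an ethyl group on its ring nitrogen would be tolerated.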